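The source may report more compounds than this note shows. Statements on the series, on what has been measured and on what is new or still open speak of the compounds shown alone.

Three compounds of the shared core have been measured in a functional assay on MGC-803 cells (Homo sapiens) for cytotoxicity, read by MTT assay, with a stated time of 72 h; on this read-out higher numbers stand for weaker inhibition and lower numbers for stronger inhibition:

compound 1 `CCNC(=O)N1CCN(C(=S)SCc2cn(Cc3ccc(F)cc3)nn2)CC1`, 2170 nM
compound 2 `Cc1ccc(Cn2cc(CSC(=S)N3CCN(C(=O)NC(C)C)CC3)nn2)cc1`, 16600 nM
compound 3 `COc1cc(Cn2cc(CSC(=S)N3CCN(C(N)=O)CC3)nn2)cc(OC)c1OC`, > 128000 nM

Among the compounds with values here, compound 3 stands apart from the other two, but only as a limit: in this assay compound 3 gives > 128000 nM, which is a limit of the assay and not a number, and it is the one value among the three that sits there (the limit of > 128000 nM in this assay, at which 1 of the 3 values shown sits). Compound 1 and compound 2 both return finite numbers, and both carry an alkyl group on the carbamoyl nitrogen, ethylcarbamoyl in compound 1 and the isopropyl analogue in compound 2, while compound 3 carries the bare carbamoyl group.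

Compound 4 `CCNC(=O)N1CCN(C(=S)SCc2cn(Cc3cc(OC)c(OC)c(OC)c3)nn2)CC1` takes the trimethoxybenzyl part of compound 3 and changes one place: ethyl in place of hydrogen on an amide-type nitrogen. The step has no measured counterpart among these compounds, so no size can be read from the data. The expected step of an at least 3.2-fold lower number from compound 3 to compound 4 (0.50 log units; beyond the scatter) is towards stronger inhibition, resting on compound 1 with its ethylcarbamoyl group and 2170 nM. Since compound 3 is known only as a limit, the true size of this step is uncertain. Compound 4 is expected to come out near 40000 nM, within a range from 8000 nM to 150000 nM.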

Compound 4, half-maximal inhibitory concentration: 101000 nM
Compound 4: the middle estimate sits 2.5-fold (0.40 log units) below what was measured, within the range that was stated.
By their numbers in this assay, from the lowest: compound 1; then compound 2; then compound 4. At a limit, above all of these: compound 3.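

In this assay compound 4, with ethyl in place of hydrogen on the amide-type nitrogen, gives 101000 nM, a finite number, so with the trimethoxybenzyl part this position can now be read on the scale of the assay. Compound 3 remains a limit of the assay and not a number: the limit of > 128000 nM in this assay, at which 1 of the 4 values shown sits. The change reads as an at least 1.2-fold lower number from compound 3 to compound 4 (0.10 log units; that floor lies within the scatter), so the data secure only a small minimum for what the ethyl group does here, and its true size could be larger but cannot be told.

Going by these compounds, it stays open whether a longer chain such as butyl, or a ring such as cyclohexyl, on this nitrogen would move the number further with the trimethoxybenzyl part in place. Also open, on these data alone, is whether the change from carbamoyl to ethylcarbamoyl would give a step of similar size with a different benzyl group, such as the 4-fluorobenzyl group of compound 1, as the bare carbamoyl group appears here only with the trimethoxybenzyl part.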